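The source may hold more compounds than are shown below. What is called first, only, known or untested is meant among the compounds shown, and "the series" means these compounds.

Measured in a functional assay on MCF7 cells (Homo sapiens) for cytotoxicity, read by MTT assay, with a stated time of 72 h; a lower number here means a stronger inhibitor, a higher number a weaker inhibitor:
compound 1 `CCc1ccc(-c2cc(C(=O)Nc3ccc(Oc4ccnc(C(=O)NC)c4)cc3)ncn2)cc1`: 6350 nM
compound 2 `CNC(=O)c1cc(Oc2ccc(NC(=O)c3cc(-c4ccc(C(F)(F)F)cc4)ncn3)cc2F)ccn1`: > 100000 nM

Compound 2 has no number in this assay. Its reading of > 100000 nM is a limit of the assay. This is the limit of > 100000 nM in this assay, at which 1 of the 2 values shown sits, so any step starting from compound 2 can be judged only loosely.

Compound 3 `CNC(=O)c1cc(Oc2ccc(NC(=O)c3cc(-c4ccc(C)cc4)ncn3)cc2F)ccn1` is the next compound to be read, with methyl in place of trifluoromethyl on an aromatic carbon, para to a large group: methyl in place of trifluoromethyl on an aromatic carbon.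

Within the data shown here, no step between measured compounds gives a guide to the size of this change. Among the measured compounds shown here, the only numerical anchor is compound 1 at 6350 nM. A move toward stronger inhibition is expected, with the estimated step being an at least 4.0-fold lower number from compound 2 to compound 3 (0.60 log units; beyond the scatter). A reading at the limit remains possible. For compound 3 the estimated value is 25000 nM, with an expected range of 5000 nM to 100000 nM.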

Compound 3, half-maximal inhibitory concentration: 19200 nM
Beside the measured number, compound 3's estimate is 1.3-fold (0.11 log units) above it; measured number inside the range.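

In this assay, methyl in place of trifluoromethyl on an aromatic carbon, para to a large group, gives an at least 5.2-fold lower number from compound 2 to compound 3 (0.71 log units; beyond the scatter) and shows that the reading responds to a change at this one position. Among these compounds, compound 3 at 19200 nM provides the first actual number for this fluorinated form of the shared core, and so a usable anchor for further changes at this position. From the compounds shown here alone, the true size of the step remains unknown because compound 2 has a limit and not a number: the limit of > 100000 nM in this assay, at which 1 of the 3 values shown sits.

Going by these compounds, whether an amine, a methoxy group or a carboxylic acid at this position would move the reading further remains open. Compound 1 differs from compound 3 in more than one place, so the effect of a longer chain such as ethyl at this position cannot be read from these compounds.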